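Benzyl amide of the series: chloro removed, cytotoxicity expected

A few compounds are considered here, and "the series" means these few. Any claim that something is new, unique, unknown or untested is made for them only; others in the source may bear on it.

Working notes on the shared core and its amide variants. Compound 1 `CC(Sc1nnc(-c2ccncc2)s1)C(=O)Nc1ccc(Cl)cc1Cl` carries a dichlorinated anilide. In an ADME assay on BHK-21 cells (Mesocricetus auratus) for cytotoxicity, with a stated time of 3 days (on this read-out lower numbers stand for higher toxicity in this test and higher numbers for lower toxicity in this test), compound 1 gives > 50000 nM, which is a limit of the assay and not a number. Compound 2 `CC(Sc1nnc(-c2ccncc2)s1)C(=O)Nc1ccccc1Cl` keeps one chloro on the anilide. In this assay compound 2 gives > 50000 nM, again a limit. The step that the two limits leave unreadable from compound 1 to compound 2 is therefore not readable; this follows from the limit of > 50000 nM in this assay, at which 2 of the 3 values shown sit. Compound 3 `CC(Sc1nnc(-c2ccncc2)s1)C(=O)NCc1ccc(Cl)cc1` is the benzyl amide with a 4-chlorophenyl; in this assay compound 3 gives "not determined" (no result reported), so no number and no limit is available for it. Compound 4 `CC(Sc1nnc(-c2ccncc2)s1)C(=O)NCc1ccccc1` is the unmeasured benzyl amide; from compound 3 it differs by hydrogen in place of chloro on an aromatic carbon. Among the measured compounds shown here, no measured step bears directly on this change, and the one measured step of the same kind, that from compound 1 to compound 2, sits at the limit on both sides. Both readable values in this assay are limits, so no effect beyond the scatter is expected for compound 4. Compound 4 is expected to give about 60000 nM, in the range 20000 nM to 200000 nM, most likely reported as a limit.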

Compound 4, half-maximal cytotoxic concentration: > 50000 nM
Compound 4: no number, only a limit; the forecaster's own chance of this, stated with the estimate: 85%; the middle value lies beyond the limit too.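

Among the compounds shown here, no step from compound 2 to compound 4 or from compound 1 to compound 4 can be read in this assay because all three compounds give a limit and not a number: the limit of > 50000 nM in this assay, at which 3 of the 4 values shown sit.
The compounds shown leave open whether any amide of the shared core gives a readable value, and how the 4-chlorobenzyl to benzyl change reads.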